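This account rests on a few compounds, and the source may have more. Where it says the series, first, only, none or still open, it means among the compounds named here.

Measured compounds:

Compound 1, `CC(C)=CCC[C@@](C)(/C=C/c1ccccc1)/C=C/c1ccc(O)cc1`. In a functional assay on NALM-6 cells (Homo sapiens) for cytotoxicity, with a stated time of 72 h (on this read-out higher numbers stand for an effect only at larger amounts of compound and lower numbers for an effect already at smaller amounts), compound 1 gives > 43400 nM, which is a limit of the assay and not a number.
Compound 2, `CC(C)=CCC[C@](C)(/C=C/c1ccc(O)cc1)/C=C/c1cccc(Cl)c1`. Here compound 2 gives > 43400 nM, again only a limit of the assay.
Compound 3, `C=C[C@@](C)(/C=C/c1ccc(-c2ccc(Cl)cc2)cc1)CCC=C(C)C`. Compound 3 gives > 43400 nM, likewise a limit of the assay.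

The change from compound 1 to compound 2 is chloro in place of hydrogen on an aromatic carbon; its step is a step that the two limits leave unreadable from compound 1 to compound 2. Compound 4, `C=C[C@@](C)(/C=C/c1ccc(-c2ccc(Cl)c(Cl)c2)cc1)CCC=C(C)C`, remains to be measured. It differs from compound 3 by chloro in place of hydrogen on an aromatic carbon, the same kind of change as from compound 1 to compound 2, but here the entering chloro sits ortho to a chloro group, a surrounding absent in the earlier pair. The difference between the cores of compound 1 and compound 3 is not broken down here. For compound 4 a step that the limit leaves unreadable from compound 3 to compound 4 is expected in this assay, because the limit of > 43400 nM in this assay, at which 3 of the 3 values shown sit, leaves no readable step among the measured compounds. Compound 4 is therefore estimated at 60000 nM, between 20000 nM and 200000 nM, most probably again reported only as a limit.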

Compound 4, half-maximal effective concentration: > 43400 nM
Compound 4: no number, only a limit (the forecaster's own chance of this, stated with the estimate: 85%); the middle value does not contradict the limit.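

No step can be read from compound 3 to compound 4 in this assay, as both give only a limit: the limit of > 43400 nM in this assay, at which 4 of the 4 values shown sit.

The compounds shown leave open whether chloro on an aromatic carbon changes cytotoxicity at all.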